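Replacing the 3-amino-4-fluorophenyl group of compound 1

The source may report more compounds than this note shows. Statements on the series, on what has been measured and on what is new or still open speak of the compounds shown alone.

Three sulfonamides have so far been measured in a functional assay on K562 cells (Homo sapiens) for cytotoxicity, read by trypan blue exclusion, with a stated time of 96 h (on this read-out lower numbers stand for stronger inhibition and higher numbers for weaker inhibition), and compound 1 (`COc1cc(OC)c(/C=C/S(=O)(=O)Nc2ccc(F)c(N)c2)c(OC)c1`) gives 5000 nM there, the lowest number of the three. Compound 3 (`O=S(=O)(/C=C/c1ccccc1)Nc1ccc(Cl)cc1`) gives 20000 nM and compound 2 (`COc1ccc(/C=C/S(=O)(=O)Nc2c(F)c(F)c(F)c(F)c2F)cc1N`) gives 35000 nM in this assay and each of these two lies on the weaker side of compound 1, beyond the usual scatter.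

Compound 4 (`COc1ccc(NS(=O)(=O)/C=C/c2c(OC)cc(OC)cc2OC)cc1`) has not yet been measured. Its difference from compound 1 is 4-methoxyphenyl in place of 3-amino-4-fluorophenyl on a sulfonamide nitrogen and it places 4-methoxyphenyl in place of 3-amino-4-fluorophenyl on a sulfonamide nitrogen. Within the data shown here, no two measured compounds differ in only one place, so the data give no direct measure of this exchange. Of the measured compounds, only compound 1 has the core that compound 4 keeps, so the expectation starts from the value of compound 1 at 5000 nM and not from the other two. The expected result in this assay is a 5.0-fold lower number from compound 1 to compound 4 (0.70 log units; beyond the scatter) as a moderate step toward stronger inhibition, beyond the scatter, although this direction remains tentative. For compound 4 the estimated value is 1000 nM with an expected range from 120 nM to 8000 nM as its limits.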

Compound 4, half-maximal inhibitory concentration: 75 nM
Compound 4: middle estimate off by 13-fold (1.12 log units), on the high side, outside the stated range (below it).
By their numbers in this assay, from the lowest: compound 4; then compound 1; then compounds 3 and 2 (each within the scatter of the next).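

Among these compounds, the exchange of 3-amino-4-fluorophenyl for 4-methoxyphenyl on a sulfonamide nitrogen is the first change in one place that can be read, and in this assay it gives a 67-fold lower number from compound 1 to compound 4 (1.82 log units; beyond the scatter) while the rest of the core of compound 1 stays as it was, so this position has a large bearing on the read-out. The two groups match in holding 8 heavy atoms, one six-membered aromatic ring of carbon only and 1 hydrogen-bond acceptor, and they differ in that the entering group has 0 hydrogen-bond donors against 1 for the leaving group and carries oxygen where the leaving group carries nitrogen and fluorine. Nothing measured here accounts for the size of this step.

Among the compounds shown here, the single step does not separate the loss of the amino group, the loss of the fluorine and the arrival of the methoxy group from one another. Also open, from the compounds shown here alone, is how a plain phenyl group, or an ethoxy group in place of the methoxy group, would read at this sulfonamide nitrogen on the same core.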